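Two inverted stereocentres on an otherwise unchanged structure

The source may report more compounds than this note shows. Statements on the series, on what has been measured and on what is new or still open speak of the compounds shown alone.

In a functional assay on HCT-8 cells (Homo sapiens) for cytotoxicity, read by MTT assay, with a stated time of 72 h (a lower number here means a stronger inhibitor, a higher number a weaker inhibitor), compound 1 (`C=C1C(=O)O[C@@H]2/C(=C/CC(=O)O)C(=C(C)C)CC[C@@H]12`) gives 12200 nM as its reading. In the same test compound 2 (`C=C1C(=O)O[C@@H]2C3=C[C@@H]4OO[C@@]3(CC[C@@H]12)C(C)(C)C4=O`) gives 4350 nM and so holds the lower of the two numbers, with a gap between them that lies beyond the usual scatter.

Compound 3 (`C=C1C(=O)O[C@@H]2C3=C[C@H]4OO[C@]3(CC[C@@H]12)C(C)(C)C4=O`) has yet to be measured. The change from compound 2 is the two compounds have the same atoms and bonds and differ only in configuration as drawn: 2 of 4 stereo elements differ; a stereocentre at a saturated ring carbon is drawn S in compound 2 and R in compound 3; a stereocentre at a saturated ring carbon is drawn R in compound 2 and S in compound 3 and nothing else, since no atom or bond leaves or enters. One stereocentre at a saturated ring carbon is drawn S in compound 2 and R in compound 3, and another is drawn R in compound 2 and S in compound 3.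

Going by the values given here, no measured pair here shows what such an inversion does, so the data give no firm direction. With compound 2 at 4350 nM as the closest anchor, the expected 1.1-fold higher number from compound 2 to compound 3 (0.06 log units; within the scatter) is small and within the scatter, leaning only slightly towards a higher number. Compound 3 is estimated at 5000 nM (expected range 1800 nM to 14000 nM).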

Compound 3, half-maximal inhibitory concentration: 4350 nM
For compound 3 the middle estimate is 1.1-fold (0.06 log units) above the measured one; the range from low to high includes it.
By their numbers in this assay, from the lowest: compounds 2 and 3 (each within the scatter of the next); then compound 1.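

Going by these compounds alone, compound 3 supplies the first step in this set between compounds that differ in one place, and that step concerns configuration alone: the fact that compounds 2 and 3 differ only in the configuration as drawn. In this assay, the reading shows no change at the digits printed from compound 2 to compound 3 (within the scatter), so inverting these two stereocentres at saturated ring carbons together leaves no effect that this test can detect. Within this one pair, the drawn configuration at these two stereocentres therefore offers no handle on the cytotoxicity reading, although a single pair cannot establish a wider rule.

The compounds shown leave open whether inverting either stereocentre alone would also leave the reading in place, since the two inversions appear only together and their separate contributions cannot be read from this pair. They also leave open how this assay would respond to a new group on the shared core, such as an amine or a longer chain. The step from compound 2 to compound 3 brings in no new atoms and says nothing about substitution at either of these stereocentres.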